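Swapping Fluorine for Chlorine on a Cytotoxicity Read-out

The compounds below may be only part of what the source reports. "The series", "measured", "known", "first", "only" and "open" are said of these compounds alone.

Of the compounds shown here, three from one series have been tested in an ADME assay on MT2 cells (Homo sapiens) for cytotoxicity, read by XTT assay, with a stated time of 4 days; on this read-out higher numbers stand for lower toxicity in this test and lower numbers for higher toxicity in this test. Compound 1, `Cc1nc(C(NC(=O)C(=O)Nc2ccc(F)cc2)C2CCCCN2)sc1CCO`, gives 109000 nM in this assay. Compound 2, `Cc1nc(C(NC(=O)C(=O)Nc2ccc(Cl)cc2)C2CCCN2)sc1CO`, gives 45000 nM in this assay. Compound 3, `Cc1nc(C(NC(=O)C(=O)NC2CCCCCC2)C2CCCCN2)sc1CO`, reaches only a limit of the assay, > 90000 nM, which is not a number; the limit of > 90000 nM in this assay, at which 1 of the 3 values shown sits, marks that edge. Among the two numbers shown, compound 1 stands highest, with compound 2 the nearest at a lower value, a gap beyond the usual scatter.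

Compound 4, `Cc1nc(C(NC(=O)C(=O)Nc2ccc(Cl)cc2)C2CCCCN2)sc1CCO`, has not yet been tested. It differs from compound 1 in one place: chloro in place of fluoro on an aromatic carbon. For the measured compounds named here, compound 2 carries the same chloro group but also differs from compound 1 in other parts of the molecule, so its lower number cannot be pinned on the chloro alone, and no single step between measured compounds isolates this change. Still, given that compound 2 gives 45000 nM while carrying chloro, a modest step toward a lower number is expected for compound 4, small enough that it may stay within the scatter. For compound 4 the expected value in this assay is 80000 nM, with a range from 40000 nM to 160000 nM. That expectation means a step from compound 1 to compound 4 of a 1.4-fold lower number from compound 1 to compound 4 (0.13 log units; within the scatter).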

Compound 4, half-maximal cytotoxic concentration: > 62000 nM
Compound 4 gave a limit, no number; the forecaster's own chance of this, stated with the estimate: 25%; the middle value does not contradict the limit.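

For the compounds shown here, no step from compound 1 to compound 4 can be read, because compound 4 reached only a limit of the assay and not a number: the limit of > 62000 nM in this assay, at which 1 of the 4 values shown sits. The compounds shown leave open whether chloro in place of fluoro on the aromatic ring changes the number in this assay at all, and if so, in which direction and by how much.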